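The source may report more compounds than this note shows. Statements on the series, on what has been measured and on what is new or still open speak of the compounds shown alone.

Working notes on the sphingosine triazole series.

Compound 3 `CCCCCCCCCCCCC/C=C/[C@@H](O)[C@H](CO)n1cc(CCCC)nn1` carries a 4-butyl-1H-1,2,3-triazol-1-yl group on the shared core and in a functional assay on HCT-116 cells (Homo sapiens) for cytotoxicity, read by sulforhodamine B assay (on this read-out higher numbers stand for an effect only at larger amounts of compound and lower numbers for an effect already at smaller amounts), compound 3 gives 12900 nM. Among the two numbers in hand this is the lower, though compound 1 `CCCCCCCCCCCCC/C=C/[C@@H](O)[C@H](CO)n1cc(CCC)nn1` with a propyl chain on the triazole sits within the scatter of it; in this assay compound 1 gives 16000 nM, a step of a 1.2-fold lower number from compound 1 to compound 3 (0.09 log units; within the scatter). Compound 2 `CCCCCCCCCCCCC/C=C/[C@@H](O)[C@H](CO)n1cc(CCCCCCCCCCCCC)nn1` with a tridecyl chain on the triazole is reported only as a limit of this assay, > 50000 nM for compound 2, so that the limit of > 50000 nM in this assay, at which 1 of the 3 values shown sits, caps what can be said of it. Lengthening the chain from compound 1 to compound 2 gives an at least 3.1-fold higher number from compound 1 to compound 2 (0.49 log units; beyond the scatter), and shortening it from compound 2 to compound 3 gives an at least 3.8-fold lower number from compound 2 to compound 3 (0.58 log units; beyond the scatter).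

Compound 4 `CCCCCCCCCCCCC/C=C/[C@@H](O)[C@H](CO)NC(C)=O` differs from compound 3 in another way: acetamido in place of 4-butyl-1H-1,2,3-triazol-1-yl on a saturated chain carbon bound to two saturated chain carbons. Among the compounds with values here, none of the measured steps touches this exchange of the whole triazole for a small amide, so they bear only indirectly; the chain steps show that a short substituent on this carbon keeps the numbers near those of compound 1 and compound 3, while a very long one pushes them to the limit. The acetamido group is small, so a step of a 1.6-fold higher number from compound 3 to compound 4 (0.19 log units; within the scatter) is expected, with no change beyond the scatter the most likely outcome. Compound 4 is therefore estimated at 20000 nM in this assay, within the range 6000 nM to 60000 nM.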

Compound 4, half-maximal effective concentration: 24500 nM
The estimate for compound 4 lay 1.2-fold (0.09 log units) below the measured number; measured number inside the range.
By their numbers in this assay, from the lowest: compounds 3, 1 and 4 (each within the scatter of the next). At a limit, above all of these: compound 2.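

In this assay, replacing the whole 4-butyl-1H-1,2,3-triazol-1-yl group with acetamido on a saturated chain carbon bound to two saturated chain carbons gives a 1.9-fold higher number from compound 3 to compound 4 (0.28 log units; within the scatter), and the same exchange for the 4-propyl-1H-1,2,3-triazol-1-yl group gives a 1.5-fold higher number from compound 1 to compound 4 (0.19 log units; within the scatter). The earlier steps shown here changed only the chain on the triazole, whereas these two show that, with a short substituent, a group with no ring and fewer heavy atoms stays within the scatter of both short-chain triazoles at this position, so compounds 1, 3 and 4 cannot be told apart here. Compound 2 remains the only compound outside this group, and its value is a limit, so no size can be given for its distance from compound 4: the limit of > 50000 nM in this assay, at which 1 of the 4 values shown sits.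

On these data alone, whether a free amine in place of acetamido, or a longer acyl chain such as octanoyl on the same nitrogen, would move the number beyond the scatter remains open. Also open is how the numbers behave with an octyl chain on the triazole, since the compounds shown do not locate where along the chain the rise to the limit begins.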